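The source may hold more compounds than are shown below. What is called first, only, known or untested is meant among the compounds shown, and "the series" means these compounds.

Working notes on the series in an ADME assay on Vero cells (Chlorocebus sabaeus) for cytotoxicity, read by MTT assay, with a stated time of 72 h; on this read-out lower numbers stand for higher toxicity in this test and higher numbers for lower toxicity in this test. Two compounds of the set have been carried through this assay. Compound 1 `CCOc1ccc(C(=O)/C=C/c2ccc(C(=O)Nc3cccc(-c4cc(C(=O)OC)no4)c3)cc2)cc1` gives > 40 ug/mL in this assay, and this is a limit of the test rather than a number. Compound 2 `COC(=O)c1cc(-c2cccc(NC(=O)c3ccc(/C=C/C(=O)c4ccccc4O)cc3)c2)on1` has no result in this assay: "not determined" (no result reported). Among the compounds with values here, compound 2 therefore stands on no number at all; the only value shown for the series is the limit of > 40 ug/mL in this assay, at which 1 of the 2 values shown sits, and no step between measured compounds can be drawn from it. Compound 3 `COC(=O)c1cc(-c2cccc(NC(=O)c3ccc(/C=C/C(=O)c4ccc(OC)c([N+](=O)[O-])c4)cc3)c2)on1` differs from compound 2 in one place: 4-methoxy-3-nitrophenyl in place of 2-hydroxyphenyl on a carbonyl carbon. Within the data shown here, with no measured step beside it, the size and direction of the change in this assay from compound 2 to compound 3 cannot be read from the data; the expectation is no change beyond the scatter, since the sole result, the limit of compound 1, points to the same region for compound 3. Compound 3 is therefore expected to give about 40 ug/mL in this assay, with a range from 20 ug/mL to 80 ug/mL, and most probably to return only the limit again.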

Compound 3, half-maximal cytotoxic concentration: > 40 ug/mL
Compound 3: only a limit was reported (the forecaster's own chance of this, stated with the estimate: 70%); the middle value lies on the limit itself.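

No step from compound 1 to compound 3 can be read in this assay, because both results are limits and not numbers: the limit of > 40 ug/mL in this assay, at which 2 of the 3 values shown sit.

Still open, as far as these compounds go, is where the half-maximal cytotoxic concentrations of compound 1 and compound 3 actually lie, and whether 4-methoxy-3-nitrophenyl in place of 4-ethoxyphenyl changes the read-out in this assay at all.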